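The compounds below may be only part of what the source reports. "The series", "measured", "known", "first", "only" and "open" are said of these compounds alone.

Compound 1 `OC(CCn1nc2c(Br)c(Br)c(Br)c(Br)c2n1)c1cccc(Br)c1` and compound 2 `OC(CCn1nc2c(Br)c(Br)c(Br)c(Br)c2n1)c1ccccc1` share the same core. In a functional assay on CCRF-CEM cells (Homo sapiens) for antiproliferative activity, read by MTT assay, with a stated time of 48 h, tested at 100 uM (a higher number here means a weaker effect of the compound at the concentration tested, a lower number a stronger effect), compound 1 gives 0% and compound 2 gives 0%. The step of no change at the digits printed from compound 1 to compound 2 (within the scatter) is hydrogen in place of bromo on an aromatic carbon, so compound 2 stands level with compound 1 at the digits shown. Compound 3 `OC(CCn1nc2c(Br)c(Br)c(Br)c(Br)c2n1)c1ccc(Br)cc1` differs from compound 2 by bromo in place of hydrogen on an aromatic carbon. Going by the values given here, the only step that bears on this, no change at the digits printed from compound 1 to compound 2 (within the scatter), also swaps hydrogen and bromo on an aromatic carbon and was flat. For compound 3 the expected step is therefore no change at the digits printed from compound 2 to compound 3 (within the scatter), none beyond the scatter. Compound 3 is estimated at 0%, with a range from 0% to 12%.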

Compound 3, a percentage reported as activity, at one concentration (the size of the read-out at that concentration, not a potency): 0%
Beside the measured number, compound 3's estimate shows no gap at the digits printed; the measured number falls inside the stated range.
By their numbers in this assay, from the lowest: compounds 1, 2 and 3 (each within the scatter of the next).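

In this assay, bromo on the aromatic carbon para to a large group gives a flat step (no change at the digits printed from compound 2 to compound 3 (within the scatter)), and 4-bromophenyl in place of 3-bromophenyl is equally flat (no change at the digits printed from compound 1 to compound 3 (within the scatter)). This ring therefore reads the same with phenyl and with either bromophenyl group shown. No available evidence accounts for this flat result.

From the compounds shown here alone, whether an amine or a carboxylic acid on this ring would shift the read-out remains open. So does the effect of a longer chain between the ring and the shared core.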